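Chain extension on the shared core: working notes

The source may report more compounds than this note shows. Statements on the series, on what has been measured and on what is new or still open speak of the compounds shown alone.

Compound 1 `Cc1nnsc1CO/N=C/c1c(C)nn(C)c1Oc1ccc(OC(F)(F)F)cc1` gives only a limit in a functional assay on PANC-1 cells (Homo sapiens) for inhibition, read by MTT assay, with a stated time of 48 h; on this read-out higher numbers stand for weaker inhibition and lower numbers for stronger inhibition: the value > 50000 nM is a limit of the assay and not a number. Compound 3 `CCc1nnsc1CO/N=C/c1c(C)nn(C)c1Oc1ccc(OC(F)(F)F)cc1` differs from compound 1 by methyl in place of hydrogen on a saturated chain carbon bound to an aromatic carbon. Compound 3 also returns a limit, > 50000 nM. The step that the two limits leave unreadable from compound 1 to compound 3 cannot be sized because of the limit of > 50000 nM in this assay, at which 3 of the 3 values shown sit. Compound 2 `CCc1nnsc1CO/N=C/c1c(C)nn(C)c1Oc1ccccc1Cl` carries a different aryl ether; the difference between the two cores is not broken down here. Compound 2 likewise gives a limit, > 50000 nM. Compound 4 `CCCc1nnsc1CO/N=C/c1c(C)nn(C)c1Oc1ccccc1Cl` has not yet been measured; it differs from compound 2 by methyl in place of hydrogen on a saturated chain carbon, two bonds along the chain from an aromatic carbon. This is the same kind of change as that from compound 1 to compound 3, the place now lying two bonds along the chain from an aromatic carbon rather than bound to an aromatic carbon. With every measured value sitting at the limit, the step from compound 2 to compound 4 is expected to remain unreadable, a step that the limit leaves unreadable from compound 2 to compound 4. For compound 4 the expected value in this assay is estimated at 100000 nM, within 50000 nM to 300000 nM, and a further limit is the most likely outcome.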

Compound 4, half-maximal inhibitory concentration: > 50000 nM
Compound 4: no number, only a limit (the forecaster's own chance of this, stated with the estimate: 90%); the middle value is on the limit's open side.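

Compound 2 and compound 4 both return a limit of the assay and not a number, so the ethyl to propyl change gives no readable step: the limit of > 50000 nM in this assay, at which 4 of the 4 values shown sit.

The compounds shown leave open what size, or even what direction, any change on the shared core would have in this assay.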